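Series notes: thiophen-2-yl to 1-benzofuran-2-yl

A few compounds are considered here, and "the series" means these few. Any claim that something is new, unique, unknown or untested is made for them only; others in the source may bear on it.

In an ADME assay on MRC5 cells (Homo sapiens), read by MTT assay, with a stated time of 72 h (on this read-out higher numbers stand for weaker inhibition and lower numbers for stronger inhibition), compound 1 (`COc1ncnc2c1c(-c1cc3ccccc3o1)cn2[C@@H]1O[C@H](CO)[C@@H](O)[C@H]1O`) gives 65600 nM, and compound 2 (`Cc1ncnc2c1c(-c1ccoc1)cn2[C@@H]1O[C@H](CO)[C@@H](O)[C@H]1O`) gives 98300 nM. Compound 3 (`Cc1ncnc2c1c(-c1cccs1)cn2[C@@H]1O[C@H](CO)[C@@H](O)[C@H]1O`) gives > 100000 nM, which is a limit of the assay and not a number. That value is the limit of > 100000 nM in this assay, at which 1 of the 3 values shown sits.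

Compound 4 (`Cc1ncnc2c1c(-c1cc3ccccc3o1)cn2[C@@H]1O[C@H](CO)[C@@H](O)[C@H]1O`) is not yet measured. It has 1-benzofuran-2-yl in place of thiophen-2-yl on an aromatic carbon.

Within the data shown here, the only measured step at this place is an at least 1.0-fold higher number from compound 2 to compound 3 (0.00 log units; that floor lies within the scatter), with thiophen-2-yl in place of furan-3-yl. It offers no size to carry over. The nearest guide is compound 1, which carries the same 1-benzofuran-2-yl group and gives 65600 nM. On that single value, a modest move to a lower number in this assay is expected, meaning stronger inhibition, though a result at the limit remains possible. The expected step is an at least 1.6-fold lower number from compound 3 to compound 4 (0.22 log units; that floor lies within the scatter). For compound 4 the estimated value is 60000 nM, with an expected range of 20000 nM to 100000 nM.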

Compound 4, half-maximal inhibitory concentration: 84400 nM
The estimate for compound 4 lay 1.4-fold (0.15 log units) below the measured number, and the stated range covers the measured number.
By their numbers in this assay, from the lowest: compounds 1, 4 and 2 (each within the scatter of the next). At a limit, above all of these: compound 3.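

With 1-benzofuran-2-yl held fixed, methyl in place of methoxy gives a 1.3-fold higher number from compound 1 to compound 4 (0.11 log units; within the scatter), so in this assay this change shows no separation between the two groups. On the aromatic carbon of the five-membered ring, 1-benzofuran-2-yl in place of furan-3-yl gives a 1.2-fold lower number from compound 2 to compound 4 (0.07 log units; within the scatter), so the added six-membered aromatic ring of carbon only brings no change beyond the scatter. The step of an at least 1.1-fold lower number from compound 3 to compound 4 (0.07 log units; that floor lies within the scatter) is only a floor, set by a limit of the assay: the limit of > 100000 nM in this assay, at which 1 of the 4 values shown sits.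

On these data alone, whether an amine or a longer chain in place of methyl would move the number beyond the scatter of compound 4 stays open. Also open is whether a phenyl group in place of 1-benzofuran-2-yl would separate from the aromatic groups shown here.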